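The source may report more compounds than this note shows. Statements on the series, on what has been measured and on what is new or still open speak of the compounds shown alone.

Compound 1 `O=C(/C=C/c1cccc(NC(=O)c2ccccc2Br)c1)c1nc2ccccc2[nH]1`: 6050 nM
Compound 2 `O=C(Nc1cccc(/C=C/C(=O)c2nc3ccccc3[nH]2)c1)c1cc(Cl)cc(Cl)c1`: 3660 nM

Both numbers come from a functional assay on 143B cells (Homo sapiens) for antiproliferative activity, read by MTT assay, with a stated time of 48 h; a lower number here means a stronger inhibitor, a higher number a weaker inhibitor. On these two numbers compound 2 sits within the scatter of compound 1: the step of a 1.7-fold lower number from compound 1 to compound 2 (0.22 log units; within the scatter) is too small to count as a real difference, so the two compounds cannot be told apart.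

Compound 3 `O=C(/C=C/c1cccc(NS(=O)(=O)c2cccc(Cl)c2)c1)c1nc2ccccc2[nH]1` has not yet been measured. It differs from compound 2 in one place: (3-chlorophenyl)sulfonyl in place of (3,5-dichlorophenyl)carbonyl on a nitrogen on an aromatic ring. For the measured compounds named here, only one measured step touches this part of the molecule, a 1.7-fold lower number from compound 1 to compound 2 (0.22 log units; within the scatter), and that step exchanged one aryl group for another on the carbonyl carbon without moving the number beyond the scatter. Going by the values given here, no measured pair exchanges the carbonyl itself for a sulfonyl, so that part of the change is untested. For compound 3 the expected step is therefore a 1.2-fold higher number from compound 2 to compound 3 (0.09 log units; within the scatter), held with wide uncertainty. Compound 3 is estimated at 4500 nM, in a range from 1500 nM to 15000 nM.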

Compound 3, half-maximal inhibitory concentration: 2510 nM
Compound 3: middle estimate off by 1.8-fold (0.25 log units), on the high side; the measured number falls inside the stated range.
By their numbers in this assay, from the lowest: compounds 3, 2 and 1 (each within the scatter of the next, the first and the last beyond it).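

In this assay, for the compounds shown here, this is the first exchange of the carbonyl for a sulfonyl on the nitrogen, and the number holds: a 1.5-fold lower number from compound 2 to compound 3 (0.16 log units; within the scatter) is too small to separate the two compounds. Going by these compounds alone, the other new step, a 2.4-fold lower number from compound 1 to compound 3 (0.38 log units; beyond the scatter), is the first in this small set to pass beyond the scatter, though only modestly; it changes the linking group and the aryl substitution at once, and neither change can be credited alone. Nothing measured here accounts for either step.

No pair shown keeps the aryl group fixed while exchanging carbonyl for sulfonyl, and the contribution of that exchange alone remains open. Also open, as far as these compounds go, is what an amine or a carboxylic acid on the aryl ring would do to the number.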